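A few compounds are considered here, and "the series" means these few. Any claim that something is new, unique, unknown or untested is made for them only; others in the source may bear on it.

In an assay on K562 cells for inhibition of Nicotinamide N-methyltransferase (Homo sapiens), read by mass spectrometry, with a stated time of 24 h (a higher number here means a weaker inhibitor, a lower number a stronger inhibitor), compound 1 `NC(=O)c1cnc2c(c1)CCN2` gives 142 nM. Compound 2 `Cc1c(C(N)=O)cnc2c1CCN2` gives 23 nM in this assay. The step of a 6.2-fold lower number from compound 1 to compound 2 (0.79 log units; beyond the scatter) shows that a methyl on that aromatic carbon of the shared core lowered the number, which means a stronger inhibitor. For the measured compounds named here, compound 2 therefore holds the lowest of the two numbers on hand, with compound 1 as its only neighbour at a higher value.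

Compound 3 `NC(=O)c1cnc2c(c1Cl)CCN2` has not yet been measured. It differs from compound 2 by chloro in place of methyl on an aromatic carbon. Going by the values given here, no measured step swaps methyl for chloro, so the only step that bears on this change is the one from hydrogen to methyl at the same carbon, a 6.2-fold lower number from compound 1 to compound 2 (0.79 log units; beyond the scatter), which shows that this carbon accepts a single heavy atom with a gain rather than a loss. The entering chloro is likewise a single heavy atom, so little movement is expected: the step is estimated as a 1.1-fold higher number from compound 2 to compound 3 (0.04 log units; within the scatter), within or near the scatter. Compound 3 is thus expected to give 25 nM in this assay, with a likely range from 8 nM to 75 nM.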

Compound 3, half-maximal inhibitory concentration: 79 nM
Compound 3: the middle estimate sits 3.2-fold (0.50 log units) below what was measured, and the stated range ends below it.
By their numbers in this assay, from the lowest: compound 2; then compounds 3 and 1 (each within the scatter of the next).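

At this aromatic carbon, opposite the ring nitrogen, the single heavy atom that enters matters: methyl and chloro each count as one heavy atom with no hydrogen-bond donors or acceptors, yet this assay shows a 3.4-fold higher number from compound 2 to compound 3 (0.54 log units; beyond the scatter) when chloro replaces methyl. Chloro also does not clearly repeat the gain that methyl brought over hydrogen, since a 1.8-fold lower number from compound 1 to compound 3 (0.25 log units; within the scatter) stays within the scatter, while a 6.2-fold lower number from compound 1 to compound 2 (0.79 log units; beyond the scatter) lies beyond it. Among these three groups, the clear gain at this carbon therefore belongs to methyl alone, and no supporting measurement is available to explain the difference between methyl and chloro here.

The compounds shown leave open how a longer chain such as ethyl, a methoxy group or an amine would fare at this same carbon, and so whether anything there can give a lower number than methyl. Going by these compounds, all three compounds also share the carbamoyl group and the rest of the core, so it remains open whether the order seen here would hold if either of those parts were changed.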